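A few compounds are considered here, and "the series" means these few. Any claim that something is new, unique, unknown or untested is made for them only; others in the source may bear on it.

Measured in a functional assay on DU-145 cells (Homo sapiens) for antiproliferative activity, read by WST assay, with a stated time of 3 days; on this read-out lower numbers stand for stronger inhibition and higher numbers for weaker inhibition:
- compound 1 `CCOc1c(-c2cc(OC)c(OC)c(OC)c2)oc2ccccc2c1=O`: 6200 nM
- compound 2 `CCN(CC)CCCOc1c(-c2cc(OC)c(OC)c(OC)c2)oc2ccccc2c1=O`: > 50000 nM (a limit)
- compound 3 `CCN(CC)CCCCCOc1c(-c2cc(OC)c(OC)c(OC)c2)oc2ccccc2c1=O`: 33400 nM

Compound 3 holds the higher of the two actual numbers, with a 5.4-fold higher number from compound 1 to compound 3 (0.73 log units; beyond the scatter). The value for compound 2 is a limit of the assay. Next is compound 4 `CCCCN(CCCC)CCCOc1c(-c2cc(OC)c(OC)c(OC)c2)oc2ccccc2c1=O`, with the change dibutylamino in place of 2-(diethylamino)ethyl on a saturated chain carbon, three bonds along the chain from an oxygen on an aromatic ring. The same difference reads 5-(diethylamino)pentyl to 3-(dibutylamino)propyl.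

Within the data shown here, three measured steps bear on this. Both amino chains raise the number, with an at least 8.0-fold higher number from compound 1 to compound 2 (0.90 log units; beyond the scatter) alongside the step to compound 3, and neither measured amine goes against this. The chain change gives an at least 1.4-fold lower number from compound 2 to compound 3 (0.17 log units; that floor lies within the scatter), a floor within the scatter. Among the measured compounds shown here, no measured step alters the groups on the nitrogen. Compound 4 keeps an amino chain, so no step beyond the scatter is expected in this assay, and the expected step is a 1.3-fold lower number from compound 3 to compound 4 (0.13 log units; within the scatter). For compound 4 the estimate is 25000 nM, with an expected range of 9000 nM to 50000 nM.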

Compound 4, half-maximal inhibitory concentration: 15700 nM
Estimate against measurement, compound 4: 1.6-fold (0.20 log units) above; measured number inside the range.
By their numbers in this assay, from the lowest: compound 1; then compound 4; then compound 3. At a limit, above all of these: compound 2.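

Among these compounds, this is the first change at the nitrogen: in this assay, dibutylamino in place of diethylamino on the same propyl chain gives an at least 3.1-fold lower number from compound 2 to compound 4 (0.50 log units; beyond the scatter). Compound 2 stands at a limit of the assay, so that step is a floor: the limit of > 50000 nM in this assay, at which 1 of the 4 values shown sits.

Set against the pentyl chain, dibutylamino on the propyl chain also gives a 2.1-fold lower number from compound 3 to compound 4 (0.33 log units; beyond the scatter), yet a 2.5-fold higher number from compound 1 to compound 4 (0.40 log units; beyond the scatter) shows that this amino chain still does not match the plain ethoxy group.

Open, from the compounds shown here alone, is how 5-(dibutylamino)pentyl would read, since it would separate chain length from the groups on the nitrogen. Also open, going by these compounds, is whether dihexylamino or a ring amine such as piperidine or morpholine on the propyl chain would bring the number closer to that of compound 1.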